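Swapping one aryl group for another on the core nitrogen

This account rests on a few compounds, and the source may have more. Where it says the series, first, only, none or still open, it means among the compounds named here.

The compounds described here share one core and differ only in the aromatic group carried on an aromatic nitrogen of that core. Compound 1 `O=C(Nc1ccc(Oc2ccnc3[nH]ccc23)c(F)c1)c1cn(-c2ccccc2)c2ccccc2c1=O` carries a plain phenyl there; in a functional assay on MCF7 cells (Homo sapiens) for inhibition, read by MTT assay, with a stated time of 72 h (on this read-out lower numbers stand for stronger inhibition and higher numbers for weaker inhibition), compound 1 gives 430 nM. Compound 2 `O=C(Nc1ccc(Oc2ccnc3[nH]ccc23)c(F)c1)c1cn(-c2ccc(Br)cc2F)c2ccccc2c1=O` carries a 4-bromo-2-fluorophenyl instead, and in this assay compound 2 gives 1390 nM. That single exchange gives a 3.2-fold higher number from compound 1 to compound 2 (0.51 log units; beyond the scatter), so the dihalogenated ring weakened inhibition by a modest but real margin. Compound 3 `O=C(Nc1ccc(Oc2ccnc3[nH]ccc23)c(F)c1)c1cn(-c2ccc(F)c(Cl)c2)c2ccccc2c1=O` carries a 3-chloro-4-fluorophenyl in the same position, but in this assay compound 3 stands at "not determined" (no result reported), so it has no number of its own to stand on. Compound 4 `COc1ccc(-n2cc(C(=O)Nc3ccc(Oc4ccnc5[nH]ccc45)c(F)c3)c(=O)c3ccccc32)cc1` is the next change: 4-methoxyphenyl in place of 3-chloro-4-fluorophenyl on an aromatic nitrogen. Compound 3 is unmeasured. Among the measured compounds shown here, the only guide is therefore the step of a 3.2-fold higher number from compound 1 to compound 2 (0.51 log units; beyond the scatter), which shows that changing the substitution on this aryl ring can move the number beyond the usual scatter, though in that case only modestly. A single methoxy-bearing ring is a different change from two halogens, so the direction is uncertain; a result somewhere between the two measured neighbours seems most plausible. For compound 4 the estimated value in this assay is 650 nM, with a range from 180 nM to 2500 nM.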

Compound 4, half-maximal inhibitory concentration: 6620 nM
Estimate against measurement, compound 4: 10-fold (1.01 log units) below, and the stated range ends below it.
By their numbers in this assay, from the lowest: compound 1; then compound 2; then compound 4.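

Adding one methoxy to the plain phenyl ring gives a 15-fold higher number from compound 1 to compound 4 (1.19 log units; beyond the scatter) in this assay and is the largest move seen at this position, so even a very small addition to this ring can weaken inhibition sharply. Compound 4 also stands clearly apart from the dihalogenated compound, with a 4.8-fold higher number from compound 2 to compound 4 (0.68 log units; beyond the scatter) on the same read-out, so the two substituted rings do not behave alike and the plain phenyl of compound 1 gives the strongest inhibition of the three measured compounds, with compound 4 the weakest. Compound 3 has no number, so the exchange of its 3-chloro-4-fluorophenyl for the 4-methoxyphenyl of compound 4 cannot be read, and this comparison rests on compound 1 and compound 2 alone.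

Why the single methoxy costs more than the bromine and fluorine together is not explained by any measurement available here. From the compounds shown here alone, it also remains open whether the loss belongs to the methoxy itself or to any group at that ring position, a question that a 4-hydroxyphenyl, a 4-methylphenyl or a 4-aminophenyl ring on the same core could help to settle.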